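The compounds below may be only part of what the source reports. "The series", "measured", "known", "first", "only" and "open" are said of these compounds alone.

Measured compounds:
- compound 1, `CCCCC(O)CC(=O)O[C@H](CC=C(C)C)C1=CC(=O)c2c(O)ccc(O)c2C1=O`: 45300 nM
- compound 2, `CC(C)=CC[C@@H](OC(=O)C1CCCO1)C1=CC(=O)c2c(O)ccc(O)c2C1=O`: 10500 nM
- compound 3, `CC(C)=CC[C@@H](OC(=O)C1CCCCO1)C1=CC(=O)c2c(O)ccc(O)c2C1=O`: 24700 nM

All three share one core and differ only in the group on the carbonyl carbon of the ester. In a functional assay on DU-145 cells (Homo sapiens) for cytotoxicity, read by MTT assay (on this read-out lower numbers stand for stronger inhibition and higher numbers for weaker inhibition), compound 2 gives the lowest number of the three, with compound 3 nearest and compound 1 furthest away; both of its steps to them are beyond the scatter.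

The unmeasured compound 4, `CCCCC(C)(O)CC(=O)O[C@H](CC=C(C)C)C1=CC(=O)c2c(O)ccc(O)c2C1=O`, departs from compound 2 as follows: 2-hydroxy-2-methylhexyl in place of oxolan-2-yl on a carbonyl carbon. Within the data shown here, two measured steps bear on this change. The step of a 4.3-fold lower number from compound 1 to compound 2 (0.63 log units; beyond the scatter) is the closest comparison, since it exchanges an open 2-hydroxyhexyl chain for the oxolan-2-yl ring at the same place; compound 4 carries a chain of that kind, now with a methyl on the hydroxyl-bearing carbon. The step of a 2.4-fold higher number from compound 2 to compound 3 (0.37 log units; beyond the scatter) shows that leaving the oxolan-2-yl ring in any direction so far has raised the number. He therefore expects compound 4 to return towards the value of compound 1, that is a modest rise in this assay beyond the scatter, roughly reversing the step from compound 1 to compound 2. For compound 4 he estimates 40000 nM, within a range from 15000 nM to 110000 nM, which means an expected step of a 3.8-fold higher number from compound 2 to compound 4 (0.58 log units; beyond the scatter).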

Compound 4, half-maximal inhibitory concentration: 76500 nM
Beside the measured number, compound 4's estimate is 1.9-fold (0.28 log units) below it; low and high end bracket the measured number.
By their numbers in this assay, from the lowest: compound 2; then compounds 3, 1 and 4 (each within the scatter of the next, the first and the last beyond it).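

In this assay the open 2-hydroxy-2-methylhexyl chain separates clearly from both ring esters, with a 7.3-fold higher number from compound 2 to compound 4 (0.86 log units; beyond the scatter) and a 3.1-fold higher number from compound 3 to compound 4 (0.49 log units; beyond the scatter); the gap to the oxolan-2-yl ester is the largest step in the set. Among these compounds, the methyl on the hydroxyl-bearing carbon, a change the earlier compounds did not probe, gives a 1.7-fold higher number from compound 1 to compound 4 (0.23 log units; within the scatter), so on this read-out it cannot be told apart from the hydrogen it replaces. Both open chains have higher numbers than compound 2, but a simple ring-over-chain rule does not hold, since compound 3 goes against it with a 1.8-fold lower number from compound 1 to compound 3 (0.26 log units; within the scatter) and so stays within the scatter of the chain ester compound 1.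

The compounds shown leave open whether the lower number of compound 2 depends on the ring oxygen, which a pyrrolidin-2-yl ring with its amine or a plain cyclopentyl ring would test, and whether a longer chain or a carboxylic acid at the chain end would shift the number at all. Nothing shown gives a reason for any of these differences.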